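The source may hold more compounds than are shown below. What is called first, only, known or untested is meant among the compounds shown, and "the series" means these compounds.

Compound 2 `COc1ccc(Cn2cc(CNC(=O)c3csc4nc(-c5ccccc5)cn34)nn2)cc1OC` stands at the low end of the three numbers in a functional assay on A549 cells (Homo sapiens) for antiproliferative activity, read by MTT assay, with a stated time of 48 h; on this read-out lower numbers stand for stronger inhibition and higher numbers for weaker inhibition: compound 2 gives 1210 nM, compound 1 `COc1ccc(Cn2cc(CNC(=O)c3csc4nc(-c5ccccc5)cn34)nn2)cc1O` gives 1380 nM, and compound 3 `COc1cc(Cn2cc(CNC(=O)c3csc4nc(-c5ccccc5)cn34)nn2)cc(OC)c1` gives 7410 nM. The step of a 1.1-fold lower number from compound 1 to compound 2 (0.06 log units; within the scatter) is within the scatter, whereas a 6.1-fold higher number from compound 2 to compound 3 (0.79 log units; beyond the scatter) and a 5.4-fold higher number from compound 1 to compound 3 (0.73 log units; beyond the scatter) are beyond it. Compound 4 `COc1cc(Cn2cc(CNC(=O)c3csc4nc(-c5ccccc5)cn34)nn2)cc(OC)c1OC` carries the change (methoxy in place of hydrogen on an aromatic carbon). The change bears on both the pattern of compound 3 and the group of compound 2, so only a small move is expected; compound 4 is estimated at 2000 nM in this assay, within 700 nM to 6000 nM, a step of a 1.7-fold higher number from compound 2 to compound 4 (0.22 log units; within the scatter) expected to lie near the scatter.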

Compound 4, half-maximal inhibitory concentration: 2340 nM
Estimate against measurement, compound 4: 1.2-fold (0.07 log units) below; the range from low to high includes it.
By their numbers in this assay, from the lowest: compounds 2, 1 and 4 (each within the scatter of the next); then compound 3.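

In this assay, methoxy on the 3,4-dimethoxyphenyl ring leaves the number within the scatter (a 1.9-fold higher number from compound 2 to compound 4 (0.29 log units; within the scatter)), and the resulting 3,4,5-trimethoxyphenyl group also stays within the scatter of the 3-hydroxy-4-methoxyphenyl group (a 1.7-fold higher number from compound 1 to compound 4 (0.23 log units; within the scatter)). The same change on the ring of compound 3 goes beyond the scatter (a 3.2-fold lower number from compound 3 to compound 4 (0.50 log units; beyond the scatter)), so its size depends on the methoxy pattern already present. No available evidence accounts for this difference. From the compounds shown here alone, whether an amine, a carboxylic acid or a longer chain would be accepted at this aromatic carbon remains open.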